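A few compounds are considered here, and "the series" means these few. Any claim that something is new, unique, unknown or untested is made for them only; others in the source may bear on it.

Measured so far in an assay on isolated protein for inhibition of Voltage-dependent L-type calcium channel subunit alpha-1C (Cavia porcellus); a lower number here means a stronger inhibitor, a higher number a weaker inhibitor:
compound 1, `CCOC(=O)C1=C(C)NC(C)=C(C(=O)OCC)C1c1[nH]cnc1Cl`: 437 nM
compound 2, `CCCOC(=O)C1=C(C)NC(C)=C(C(=O)OCCC)C1c1[nH]cnc1Cl`: 63.1 nM
compound 3, `CC1=C(C(=O)OC2CCCC2)C(c2[nH]cnc2Cl)C(C(=O)OC2CCCC2)=C(C)N1`: 97.7 nM

Compound 1 stands highest of the three numbers; compound 3 lies nearest to it and compound 2 furthest, both gaps beyond the scatter. Within the data shown here, no pair of measured compounds differs in only one place, so no single step is known. Compound 4, `CCOC(=O)C1=C(C)NC(C)=C(C(=O)OCC2CCCCC2)C1c1[nH]cnc1Cl`, differs from compound 1 by cyclohexyl in place of methyl on a saturated chain carbon bound to an oxygen next to a carbonyl group. Both larger esters among the measured compounds go with lower numbers than compound 1, though each is changed on both ester groups at once, whereas compound 4 is changed on one. A downward step beyond the scatter is expected, a 4.0-fold lower number from compound 1 to compound 4 (0.60 log units; beyond the scatter). Compound 4 is expected to give about 110 nM in this assay, within 40 nM to 300 nM.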

Compound 4, half-maximal inhibitory concentration: 513 nM
The estimate for compound 4 lay 4.7-fold (0.67 log units) below the measured number; measured number outside the range, above it.
By their numbers in this assay, from the lowest: compounds 2 and 3 (each within the scatter of the next); then compounds 1 and 4 (each within the scatter of the next).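

Cyclohexyl in place of methyl on a saturated chain carbon bound to an oxygen next to a carbonyl group gives a 1.2-fold higher number from compound 1 to compound 4 (0.07 log units; within the scatter) in this assay. Among these compounds, as the first single-place step, it shows that this much larger group, on one ester only, leaves the number within the scatter. No measurement at hand accounts for this result.

Still open, as far as these compounds go, is whether the same change on both ester groups would move the number beyond the scatter. From the compounds shown here alone, a longer chain, an amine or a carboxylic acid on this ester also remains untested here.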